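This account rests on a few compounds, and the source may have more. Where it says the series, first, only, none or still open, it means among the compounds named here.

Measured so far:
Compound 1 `Oc1ccc(-c2cc(-c3ccco3)cc(-c3ccccc3O)n2)cc1` gives 83% in an assay on isolated protein for inhibition of DNA topoisomerase 1 (Homo sapiens), with a stated time of 30 min, tested at 100 uM; a higher number here means a stronger effect of the compound at the concentration tested, a lower number a weaker effect.
Compound 2 `Oc1ccccc1-c1cc(-c2ccccn2)cc(-c2ccccc2O)n1` gives 0.8% in this assay.

For the measured compounds named here, compound 2 stands lowest of the two numbers; compound 1 is the only other measured compound, and its value lies beyond the scatter above that of compound 2. Compound 3 `Oc1ccc(-c2cc(-c3ccccn3)cc(-c3ccccc3O)n2)cc1` has not yet been measured. It differs from compound 2 by 4-hydroxyphenyl in place of 2-hydroxyphenyl on an aromatic carbon. Going by the values given here, no step between measured compounds isolates this change, so its size is open; compound 1, which carries a 4-hydroxyphenyl group and gives 83%, hints that compound 3 may rise. An upward step a number 39.2 percentage points higher from compound 2 to compound 3 (beyond the scatter) is expected, and compound 3 is estimated at 40%, within 5% to 80%.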

Compound 3, a percentage reported as inhibition, at one concentration (the size of the read-out at that concentration, not a potency): 0.2%
Compound 3: middle estimate off by 39.8 percentage points, on the high side; measured number below the stated range.
By their numbers in this assay, from the lowest: compounds 3 and 2 (each within the scatter of the next); then compound 1.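

In this assay, 4-hydroxyphenyl in place of 2-hydroxyphenyl at this position gives a number 0.6 percentage points lower from compound 2 to compound 3 (within the scatter), so with pyridin-2-yl present this change makes no readable difference. The large change comes instead with pyridin-2-yl in place of furan-2-yl, which gives a number 82.8 percentage points lower from compound 1 to compound 3 (beyond the scatter), and so the 4-hydroxyphenyl group alone does not carry the effect seen for compound 1. Nothing measured here gives a reason for either step. Still open, going by these compounds, is whether 2-hydroxyphenyl would matter alongside furan-2-yl. Also open, on these data alone, is how a thiophen-2-yl group would compare with furan-2-yl.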